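The source may report more compounds than this note shows. Statements on the series, on what has been measured and on what is new or still open speak of the compounds shown alone.

Measured so far in an ADME assay on L02 cells (Homo sapiens) for cytotoxicity, read by MTT assay, with a stated time of 24 h; a lower number here means a stronger inhibitor, a higher number a weaker inhibitor: compound 1 `O=C1/C(=C/c2ccccc2F)CN(S(=O)(=O)c2ccc(F)cc2)C/C1=C\c1ccccc1F` gives 17500 nM; compound 2 `CC(=O)Nc1ccc(S(=O)(=O)N2C/C(=C\c3ccccc3F)C(=O)/C(=C/c3ccccc3F)C2)cc1` gives 11500 nM; compound 3 `O=C1/C(=C/c2cccc(F)c2)CN(S(=O)(=O)c2ccc(O[N+](=O)[O-])cc2)C/C1=C\c1cccc(F)c1` gives 10700 nM.

All three numbers lie within the scatter of one another, so compound 3 is not set apart from compound 1 or compound 2 on these values. For the measured compounds named here, the one step between measured compounds, a 1.5-fold lower number from compound 1 to compound 2 (0.18 log units; within the scatter), also alters the group on the aromatic carbon para to a large group and stays within the scatter.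

Compound 4 `N#Cc1ccc(S(=O)(=O)N2C/C(=C\c3cccc(F)c3)C(=O)/C(=C/c3cccc(F)c3)C2)cc1` differs from compound 3 by cyano in place of nitrooxy on an aromatic carbon. Going by the values given here, as the only comparable step is within the scatter, no shift beyond it is expected in this assay: the expected step is a 1.0-fold higher number from compound 3 to compound 4 (0.01 log units; within the scatter). Compound 4 is estimated at 11000 nM, between 5000 nM and 25000 nM.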

Compound 4, half-maximal inhibitory concentration: 15500 nM
Compound 4: middle estimate off by 1.4-fold (0.15 log units), on the low side; the range from low to high includes it.
By their numbers in this assay, from the lowest: compounds 3, 2, 4 and 1 (each within the scatter of the next).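

In this assay the exchange of 4-(nitrooxy)phenyl for 4-cyanophenyl gives a 1.4-fold higher number from compound 3 to compound 4 (0.16 log units; within the scatter) and so does not separate the two compounds. Cyano, with fewer heavy atoms and no oxygen, is thus tolerated at this place, para to a large group, without a shift beyond the scatter, and this is the second such step there. No measurement offered here bears on the reason for this result.

From the compounds shown here alone, whether an amine or a carboxylic acid at this place would move the number beyond the scatter remains open.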